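Replacing chloro with iodo: what the step may bring

The compounds below may be only part of what the source reports. "The series", "measured", "known", "first", "only" and "open" are said of these compounds alone.

Values in a functional assay on AGS cells (Homo sapiens) for inhibition, read by reporter gene assay; on this read-out higher numbers stand for weaker inhibition and lower numbers for stronger inhibition:
- Compound 1 `Cc1ccc(OCC(=O)Nc2cccc(C(=O)O)c2)cc1`: > 30000 nM (a limit)
- Compound 2 `O=C(COc1ccc(F)cc1)Nc1cccc(C(=O)O)c1`: > 30000 nM (a limit)
- Compound 3 `O=C(COc1ccc(Cl)cc1)Nc1cccc(C(=O)O)c1`: 10000 nM

Among the compounds with values here, compound 3 gives the only true number of the three and is the strongest inhibitor among them. The rest of the picture is the limit of > 30000 nM in this assay, at which 2 of the 3 values shown sit, so neither of the other compounds gives a number to compare directly.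

The next compound, compound 4 `O=C(COc1ccc(I)cc1)Nc1cccc(C(=O)O)c1`, changes one group: iodo in place of chloro on an aromatic carbon.

Within the data shown here, two measured steps bear on this change, both made at that same place. One is an at least 3.0-fold lower number from compound 2 to compound 3 (0.47 log units; beyond the scatter) and the other is an at least 3.0-fold lower number from compound 1 to compound 3 (0.47 log units; beyond the scatter), so each gives only a minimum size. The step that the two limits leave unreadable from compound 1 to compound 2 tells nothing further. Iodo itself has not yet been measured here.

Going by an at least 3.0-fold lower number from compound 2 to compound 3 (0.47 log units; beyond the scatter), a modest further fall in this assay is expected, though it may stay within the scatter. The expected change is a 2.0-fold lower number from compound 3 to compound 4 (0.30 log units; within the scatter). Compound 4 is estimated at 5000 nM, with an expected range of 1500 nM to 20000 nM.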

Compound 4, half-maximal inhibitory concentration: 3500 nM
Compound 4: the middle estimate sits 1.4-fold (0.15 log units) above what was measured, within the range that was stated.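

Swapping chloro for iodo gives a 2.9-fold lower number from compound 3 to compound 4 (0.46 log units; beyond the scatter), so this position still responds to a change of one heavy atom, and the drop seen from fluoro to chloro continues with iodo. Iodo is now the strongest group of the four at this place in this assay, giving an at least 8.5-fold lower number from compound 2 to compound 4 (0.93 log units; beyond the scatter) and an at least 8.5-fold lower number from compound 1 to compound 4 (0.93 log units; beyond the scatter). These two wider steps give only minimum sizes because their starting compounds have no true number: the limit of > 30000 nM in this assay, at which 2 of the 4 values shown sit.

On these data alone, it remains open whether the trend extends to other groups at this place, such as trifluoromethyl, nitrile or methoxy, or whether iodo marks its end. As far as these compounds go, it is also open whether the same order would hold if the carboxylic acid on the shared core were replaced by an ester or an amide.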